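The source may hold more compounds than are shown below. What is called first, only, known or untested is meant among the compounds shown, and "the series" means these compounds.

Measured so far in an ADME assay on HeLa cells (Homo sapiens) for cytotoxicity, read by MTT assay; on this read-out higher numbers stand for weaker inhibition and lower numbers for stronger inhibition:
- Compound 1 `OCCNc1ccnc2cc(Cl)ccc12`: > 100000 nM, a limit of the assay
- Compound 2 `NCCCCCNc1ccnc2cc(Cl)ccc12`: 56600 nM

Going by the values given here, compound 2, at 56600 nM, holds the only actual number in this assay so far. Compound 1 is reported only as a limit, > 100000 nM.

The next compound is compound 3 `NCCNc1ccnc2cc(Cl)ccc12`, which shortens the chain of compound 2: amino in place of 3-aminopropyl on a saturated chain carbon, two bonds along the chain from a nitrogen on an aromatic ring. This places amino in place of 3-aminopropyl on a saturated chain carbon, two bonds along the chain from a nitrogen on an aromatic ring. Cut one bond further out, the same difference reads 5-aminopentyl to 2-aminoethyl.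

Among the compounds with values here, one measured step bears on this change, at the same place: an at least 1.7-fold lower number from compound 1 to compound 2 (0.24 log units; that floor lies within the scatter). Within the data shown here, it gives only a floor, not a true size, and no measured step isolates chain length. Going by that step to compound 2, a small move toward a higher number is expected, perhaps none beyond the scatter, and another limit is possible.

The estimated step is a 1.2-fold higher number from compound 2 to compound 3 (0.09 log units; within the scatter). For compound 3 the estimate is 70000 nM, with an expected range of 25000 nM to 120000 nM.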

Compound 3, half-maximal inhibitory concentration: 63400 nM
For compound 3 the middle estimate is 1.1-fold (0.04 log units) above the measured one; the measured number falls inside the stated range.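

In this assay, going by these compounds alone, the first measured look at chain length on its own gives a 1.1-fold higher number from compound 2 to compound 3 (0.05 log units; within the scatter), so with amino in place of 3-aminopropyl at this saturated chain carbon, the two amine-ended chains cannot be told apart. The comparison of the amine-ended 2-aminoethyl chain with the hydroxy-ended chain gives an at least 1.5-fold lower number from compound 1 to compound 3 (0.19 log units; that floor lies within the scatter), which is a floor and not a true size, and it again stays within the scatter, as the earlier floor did. Compound 1 is reported only as a limit, so neither floor shows how far the hydroxy end truly lies from the amine ends: the limit of > 100000 nM in this assay, at which 1 of the 3 values shown sits.

The compounds shown leave open whether a chain longer than 5-aminopentyl would keep the number in this same range, since only these two lengths of amine-ended chain can be compared. They also leave open how a dimethylamino group or a carboxylic acid at the end of the chain would read in this assay, and whether any such group would give a step beyond the scatter.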